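The source may report more compounds than this note shows. Statements on the series, on what has been measured and on what is new or still open speak of the compounds shown alone.

Measured compounds:
compound 1 `CC1=CSC(O)(c2ccc([N+](=O)[O-])cc2)c2noc(=O)n21`: > 100000 nM
compound 2 `CC1=CSC(O)(c2cccc([N+](=O)[O-])c2)c2noc(=O)n21`: 129000 nM

Both were tested in a functional assay on A2780/DX3 cells (Homo sapiens) for antiproliferative activity, read by MTT assay, with a stated time of 3 days; on this read-out higher numbers stand for weaker inhibition and lower numbers for stronger inhibition. Compound 1 gives > 100000 nM, which is a limit of the assay and not a number. On the numbers shown, compound 1 therefore stands only as a limit; (the limit of > 100000 nM in this assay, at which 1 of the 2 values shown sits). Compound 2, by contrast, gives an actual number, 129000 nM, and that number is itself very weak. Among the compounds with values here, no step between compound 1 and compound 2 is drawn here, so all that can be said is that both values show little inhibition.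

Compound 3 `CC1=CSC(O)(c2ccc(C)cc2)c2noc(=O)n21` differs from compound 1 in one place: methyl in place of nitro on an aromatic carbon. Within the data shown here, no measured step is available for this kind of change on this core, so there is no guide to its direction or size. Given that compound 1 sits at a limit, the change is expected to give no step beyond the scatter. The estimate for compound 3 is 100000 nM, with a range from 30000 nM to 300000 nM, which corresponds to an expected step of a number no higher from compound 1 to compound 3 (the limit leaves the size open).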

Compound 3, half-maximal inhibitory concentration: > 100000 nM
Compound 3: only a limit was reported; the forecaster's own chance of this, stated with the estimate: 50%; the middle value sits exactly at the limit.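

In this assay compound 3 gives > 100000 nM, which is a limit and not a number. Compound 1 also stands only as a limit, so no step from compound 1 to compound 3 can be read: the limit of > 100000 nM in this assay, at which 2 of the 3 values shown sit.

The compounds shown leave open how strongly either one inhibits, and whether methyl in place of nitro on an aromatic carbon changes that at all.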